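This account rests on a few compounds, and the source may have more. Where it says the series, first, only, none or still open, it means among the compounds named here.

Measured compounds:
Compound 1, `O=C(Nc1ccc(Oc2ccnc3[nH]ccc23)cc1)c1nn(-c2ccc(Cl)cc2)ccc1=O`: 25100 nM
Compound 2, `COc1ccc(-n2ccc(=O)c(C(=O)Nc3ccc(Oc4ccnc5[nH]ccc45)cc3)n2)cc1`: 53100 nM
Compound 3, `O=C(Nc1ccc(Oc2ccnc3[nH]ccc23)cc1)c1nn(-c2ccc(Cl)c(F)c2)ccc1=O`: 2580 nM

These three compounds share one core and differ only in the aryl group attached to the ring nitrogen of that core. In a functional assay on A549 cells (Homo sapiens) for cytotoxicity, read by MTT assay, with a stated time of 72 h (on this read-out higher numbers stand for weaker inhibition and lower numbers for stronger inhibition), compound 2 gives 53100 nM, the highest number of the three, meaning the weakest inhibition seen here. Its nearest neighbour is compound 1. The step of a 2.1-fold higher number from compound 1 to compound 2 (0.33 log units; beyond the scatter) records this small gap, and compound 3 sits far lower, as the step of a 21-fold lower number from compound 2 to compound 3 (1.31 log units; beyond the scatter) records.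

Compound 4, `COc1ccc(-n2ccc(=O)c(C(=O)Nc3ccc(Oc4ccnc5c4ccn5C)cc3)n2)cc1`, keeps the whole of compound 2 except for one change: methyl in place of hydrogen on an aromatic nitrogen. The measured steps all concern the aryl group on the other ring nitrogen: a 2.1-fold higher number from compound 1 to compound 2 (0.33 log units; beyond the scatter) and a 9.7-fold lower number from compound 1 to compound 3 (0.99 log units; beyond the scatter). None of them touches the five-membered ring where the new methyl enters, so they give no direct guide to this change. With nothing in the data speaking for a shift in either direction, the expected step of a 1.3-fold higher number from compound 2 to compound 4 (0.12 log units; within the scatter) in this assay is set close to no change, with a slight lean toward a higher number. Compound 4 is therefore estimated at 70000 nM, within a range from 25000 nM to 200000 nM.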

Compound 4, half-maximal inhibitory concentration: > 60000 nM
Compound 4 gave a limit, no number; the forecaster's own chance of this, stated with the estimate: 30%; the middle value is on the limit's open side.
By their numbers in this assay, from the lowest: compound 3; then compound 1; then compound 2. At a limit, above all of these: compound 4.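

The methyl on the aromatic nitrogen of the five-membered ring is the first change shown in this part of the molecule, as the earlier compounds differ only in the aryl group on the other ring nitrogen. In this assay compound 4 gives a limit of the assay and not a number: the limit of > 60000 nM in this assay, at which 1 of the 4 values shown sits. The step is therefore only a floor, an at least 1.1-fold higher number from compound 2 to compound 4 (0.05 log units; that floor lies within the scatter), so methyl in place of hydrogen at this position brings no visible gain in inhibition over compound 2, while whether compound 4 truly differs from compound 2, and by how much, cannot be read.

From the compounds shown here alone, compound 2 already has the highest number among the measured values, so the effect of the same methyl on compound 3, with its 4-chloro-3-fluorophenyl group and much stronger inhibition, remains open. Also open, going by these compounds, is whether a different group on this nitrogen, such as an ethyl, a longer chain ending in an amine, or a carboxylic acid, would leave the number unchanged or move it in either direction.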